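Removing a Methoxy Group from a Trimethoxy Chalcone

The compounds below may be only part of what the source reports. "The series", "measured", "known", "first", "only" and "open" are said of these compounds alone.

Compound 2 `COc1cc(OC)c(OC)cc1/C=C/C(=O)c1ccccc1F` gives 55.3 nM in a functional assay on HCT-15 cells (Homo sapiens) for cytotoxicity, read by MTT assay, with a stated time of 72 h (on this read-out lower numbers stand for stronger inhibition and higher numbers for weaker inhibition), which puts it at the lowest of the two numbers seen, though compound 1 `COc1ccc(/C=C/C(=O)c2ccccc2F)c(OC)c1` sits at 55.9 nM in this assay and the two stand within the scatter of each other. For the measured compounds named here, the single measured step, a 1.0-fold lower number from compound 1 to compound 2 (0.00 log units; within the scatter), shows that adding a methoxy made no difference. Compound 3 `COc1ccc(OC)c(/C=C/C(=O)c2ccccc2F)c1` differs from compound 2 by hydrogen in place of methoxy on an aromatic carbon. Given that the one relevant step was flat, compound 3 is expected to stay close, with a 1.1-fold higher number from compound 2 to compound 3 (0.04 log units; within the scatter) and an estimated 60 nM in this assay, ranging from 25 nM to 150 nM.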

Compound 3, half-maximal inhibitory concentration: 61.1 nM
Compound 3: middle estimate off by 1.0-fold (0.01 log units), on the low side; measured number inside the range.
By their numbers in this assay, from the lowest: compounds 2, 1 and 3 (each within the scatter of the next).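

In this assay the change shows as a 1.1-fold higher number from compound 2 to compound 3 (0.04 log units; within the scatter), so the methoxy para to a large group can give way to hydrogen with no readable change. The earlier step had shown this for a different methoxy only; now two of the methoxy groups of compound 2 have each proved replaceable by hydrogen, one at a time. No available evidence bears on this result. As far as these compounds go, whether an amine or a carboxylic acid at this position would leave the number as flat stays open, as does the loss of both methoxy groups together.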